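Swapping the phenyl for pyridin-4-yl on the shared core

This account rests on a few compounds, and the source may have more. Where it says the series, first, only, none or still open, it means among the compounds named here.

The measured compounds and their values in a functional assay on NCI-H2122 cells (Homo sapiens) for inhibition, read by microscopy, with a stated time of 10 days; a lower number here means a stronger inhibitor, a higher number a weaker inhibitor:

- compound 1, `Cn1nc(-c2ccccc2)c2c1OC(N)=C(C#N)C2c1ccccc1`: compound 1 reaches only the assay limit of > 10000 nM.
- compound 2, `Cn1nc(-c2ccccc2)c2c1OC(N)=C(C#N)C2c1ccc(C(F)(F)F)cc1`: compound 2 gives 4100 nM.
- compound 3, `Cn1nc(-c2ccccc2)c2c1OC(N)=C(C#N)C2c1ccc(OC(F)(F)F)cc1`: compound 3 gives 5500 nM.

Compound 1 stands at the edge of what this assay reports: its value is a limit, not a number (the limit of > 10000 nM in this assay, at which 1 of the 3 values shown sits), so its true potency is known only to be weaker than that boundary. Compound 4, `Cn1nc(-c2ccccc2)c2c1OC(N)=C(C#N)C2c1ccncc1`, differs from compound 1 in one place: pyridin-4-yl in place of phenyl on a saturated ring carbon.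

Within the data shown here, two measured steps touch the same aromatic ring on that saturated ring carbon. Adding a trifluoromethyl gave an at least 2.4-fold lower number from compound 1 to compound 2 (0.38 log units; beyond the scatter), and adding a trifluoromethoxy gave an at least 1.8-fold lower number from compound 1 to compound 3 (0.25 log units; that floor lies within the scatter); between those two products the gap is a 1.3-fold higher number from compound 2 to compound 3 (0.13 log units; within the scatter). Both steps decorate the phenyl rather than replace it, so neither tells directly what exchanging the whole ring for pyridin-4-yl does. Among the measured compounds shown here, the only firm point is that the unsubstituted phenyl of compound 1 sits at the limit, and a ring change of this kind has no measured precedent here.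

Compound 4 is therefore expected to land near the limit again, estimated at 10000 nM with a range from 3000 nM to 30000 nM, which would mean a step of a number no higher from compound 1 to compound 4 (the limit leaves the size open).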

Compound 4, half-maximal inhibitory concentration: 5200 nM
Beside the measured number, compound 4's estimate is 1.9-fold (0.28 log units) above it, within the range that was stated.
By their numbers in this assay, from the lowest: compounds 2, 4 and 3 (each within the scatter of the next). At a limit, above all of these: compound 1.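

Among these compounds, at this saturated ring carbon, exchanging the whole ring also yields a measurable value in this assay, something that only groups added to the phenyl had done among the earlier compounds: the step is an at least 1.9-fold lower number from compound 1 to compound 4 (0.28 log units; that floor lies within the scatter). Pyridin-4-yl carries the same count of heavy atoms as phenyl, with one ring carbon exchanged for nitrogen and one hydrogen-bond acceptor gained, so a change inside the ring itself, with no group added to it, is enough for compound 4 to give a number. The true size of this step stays unknown because compound 1 has only a limit and not a number: the limit of > 10000 nM in this assay, at which 1 of the 4 values shown sits.

The compounds shown leave open whether the place of the ring nitrogen matters, which pyridin-3-yl and pyridin-2-yl at the same carbon would address, and whether a trifluoromethyl on the pyridine ring would add to what the nitrogen does. They also leave open how an amine or a carboxylic acid on this ring would read in this assay, and whether any group here could bring the number far lower.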